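Dropping One Bromo Group: From Compound 1 to Compound 3

This account rests on a few compounds, and the source may have more. Where it says the series, first, only, none or still open, it means among the compounds named here.

Measured compounds:
compound 1, `Brc1ccc(OCCOc2nc3ccccc3s2)c(Br)c1`, 68.6%
compound 2, `c1ccc(COc2nc3ccccc3s2)cc1`, 51.9%

Of the compounds shown here, two have been measured in a functional assay on the whole organism with Mus musculus as the target, in the writhing test, at a dose of 100 mg/kg by the intraperitoneal route; a higher number here means more inhibition at the dose given (going by the name of the read-out), a lower number less inhibition. Compound 1 gives 68.6% in this assay, the highest of the two numbers. Its nearest neighbour is compound 2, which gives 51.9% in this assay, a number lower by an amount beyond the usual scatter. Compound 2 carries no bromo groups and a shorter link to the shared core, so the two differ in more than one place, and their two values alone say nothing about a single change.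

Compound 3, `Brc1ccc(OCCOc2nc3ccccc3s2)cc1`, has not been measured. It differs from compound 1 in one place: hydrogen in place of bromo on an aromatic carbon. One of the two bromo groups leaves and a hydrogen enters in its place.

Among the measured compounds shown here, no pair of measured compounds differs in one place, so there is no step to lean on. The account therefore expects a small step downward, or none beyond the scatter. Compound 3 is expected to give 60% in this assay, within an estimated range from 44% to 76%. The expected step of a number 8.6 percentage points lower from compound 1 to compound 3 (within the scatter) is estimated to fall at or near the edge of the scatter.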

Compound 3, a percentage reported as inhibition, in the whole organism at one dose (the size of the read-out at that dose, not a potency): 68.6%
For compound 3 the middle estimate is 8.6 percentage points below the measured one; low and high end bracket the measured number.
By their numbers in this assay, from the lowest: compound 2; then compounds 1 and 3 (each within the scatter of the next).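

In this assay, putting hydrogen in place of bromo on an aromatic carbon, ortho to a large group and meta to the other bromo group, gives no change at the digits printed from compound 1 to compound 3 (within the scatter) and provides the first single change that can be read among these compounds. At this one dose, the inhibition therefore does not depend on the bromo group at this position, and that heavy atom can leave without a step beyond the scatter. The read-out gives the size of the effect at one dose rather than a potency, and nothing on hand gives a reason for this result.

Going by these compounds, it remains open whether the bromo group still present in compound 3 can also leave without a step beyond the scatter, and whether an amine or a carboxylic acid at the position now carrying hydrogen would leave the inhibition unchanged. The contribution of the link to the shared core also stays unresolved: compound 2 differs from compound 1 and compound 3 in more than one place, and no compound shown carries a longer chain there.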